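The source may hold more compounds than are shown below. What is called first, only, known or untested is meant among the compounds shown, and "the series" means these compounds.

Compound 2, `O=C(CCCCCCc1ccccc1)c1nc(C(F)(F)F)co1`, was measured in an assay on HEK-293T cells for inhibition of diacylglycerol lipase-alpha (Homo sapiens), read by colorimetric assay (on this read-out higher numbers stand for weaker inhibition and lower numbers for stronger inhibition), and gave 214 nM. Among the two numbers recorded so far it carries the highest value, yet its nearest neighbour, compound 1, `O=C(CCCCCc1ccccc1)c1nc2cnccc2o1`, gave 204 nM in this assay, and the two lie within the usual scatter of each other, so nothing separates them. Compound 3, `O=C(CCCCCCc1ccccc1)c1nc(-c2ccncc2)co1`, has not yet been measured in this assay. It differs from compound 2 in one place: pyridin-4-yl in place of trifluoromethyl on an aromatic carbon. Among the compounds with values here, no pair of measured compounds shows what such an exchange does on this read-out, so no step size can be drawn from the data. The account expects the step from compound 2 to compound 3 in this assay to be a 1.4-fold lower number from compound 2 to compound 3 (0.15 log units; within the scatter), a modest gain at most and possibly none beyond the scatter. Compound 3 is therefore estimated at 150 nM, with a range from 40 nM to 600 nM.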

Compound 3, half-maximal inhibitory concentration: > 10000 nM
Compound 3: no number, only a limit; the forecaster's own chance of this, stated with the estimate: 5%; at least 66-fold (1.82 log units) between middle value and limit.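

In this assay, within the data shown here, this exchange is the first measured step at the aromatic carbon next to the ring nitrogen, and it is large: pyridin-4-yl in place of trifluoromethyl gives an at least 46-fold higher number from compound 2 to compound 3 (1.66 log units; beyond the scatter). The position is therefore not indifferent to the group it carries, and with the chain and the rest of the molecule unchanged, this one exchange is enough to produce the step. Compound 3 gives no number, only a limit of the assay, so the full size of the step stays unknown: the limit of > 10000 nM in this assay, at which 1 of the 3 values shown sits.

The compounds shown do not tell whether the step follows from losing trifluoromethyl or from bringing in pyridin-4-yl. As far as these compounds go, it also remains open how a phenyl ring, a methyl group or a nitrile would fare at this position.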